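The source may hold more compounds than are shown below. What is called first, only, known or untested is meant among the compounds shown, and "the series" means these compounds.

In a functional assay on MDA-MB-231 cells (Homo sapiens) for inhibition, read by MTT assay, with a stated time of 72 h (a lower number here means a stronger inhibitor, a higher number a weaker inhibitor), compound 1 `c1ccc(-c2nc(CNc3nccc(NC4CC4)n3)cs2)cc1` gives > 100000 nM as a limit of the assay and not a number. Within the data shown here, compound 2 `CCCCN(CCCC)c1ccnc(NCc2csc(-c3ccccc3)n2)n1` gives 21700 nM and compound 3 `c1ccc(-c2nc(CNc3nccc(N4CCCC4)n3)cs2)cc1` gives 18300 nM as the only two true numbers. These two values lie within the scatter of each other, as a 1.2-fold lower number from compound 2 to compound 3 (0.07 log units; within the scatter) shows, so compound 3 stands level with compound 2. Both stand apart from compound 1, with an at least 4.6-fold lower number from compound 1 to compound 2 (0.66 log units; beyond the scatter) and an at least 5.4-fold lower number from compound 1 to compound 3 (0.73 log units; beyond the scatter) as the measured steps, each beyond the scatter.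

Compound 4 `c1ccc(-c2nc(CNc3nccc(N4CCCCC4)n3)cs2)cc1` has piperidin-1-yl in place of pyrrolidin-1-yl on an aromatic carbon, opposite the ring nitrogen piperidin-1-yl in place of pyrrolidin-1-yl on an aromatic carbon on the shared core. Among the measured compounds shown here, no measured step makes this exact exchange. The closest guide is a 1.2-fold lower number from compound 2 to compound 3 (0.07 log units; within the scatter), where replacing dibutylamino with pyrrolidin-1-yl moved the number no further than the scatter. The larger steps, an at least 4.6-fold lower number from compound 1 to compound 2 (0.66 log units; beyond the scatter) and an at least 5.4-fold lower number from compound 1 to compound 3 (0.73 log units; beyond the scatter), both start from cyclopropylamino, which compound 4 does not involve. No step beyond the scatter is therefore expected in this assay, and the estimated change is a 1.1-fold lower number from compound 3 to compound 4 (0.06 log units; within the scatter) in size. For compound 4 the expected value is 16000 nM, with an estimated range from 6500 nM to 42000 nM.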

Compound 4, half-maximal inhibitory concentration: 14600 nM
Beside the measured number, compound 4's estimate is 1.1-fold (0.04 log units) above it; low and high end bracket the measured number.
By their numbers in this assay, from the lowest: compounds 4, 3 and 2 (each within the scatter of the next). At a limit, above all of these: compound 1.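

In this assay, piperidin-1-yl in place of pyrrolidin-1-yl on this aromatic carbon, opposite the ring nitrogen, gives no separation beyond the scatter, with a 1.3-fold lower number from compound 3 to compound 4 (0.10 log units; within the scatter). The six-membered ring also stands level with the open-chain dibutylamino, with a 1.5-fold lower number from compound 2 to compound 4 (0.17 log units; within the scatter), so a five-membered ring, a six-membered ring and two butyl chains on this nitrogen cannot be told apart here. Compound 4 stands clearly apart only from compound 1, with an at least 6.8-fold lower number from compound 1 to compound 4 (0.83 log units; beyond the scatter), a step that can be read only as a bound because compound 1 stands at a limit: the limit of > 100000 nM in this assay, at which 1 of the 4 values shown sits.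

Going by these compounds, it remains open whether any other group at this position would move the number beyond the scatter of these three compounds, for instance morpholin-4-yl, a piperazine or the seven-membered azepane. On these data alone, it also remains open whether the gap to cyclopropylamino goes with the hydrogen on that nitrogen or with the small ring, which a pair such as methylamino and dimethylamino could help to separate.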